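Polar side chain in place of a fluorophenyl group

A few compounds are considered here, and "the series" means these few. Any claim that something is new, unique, unknown or untested is made for them only; others in the source may bear on it.

an ADME assay (Homo sapiens) for cytotoxicity (on this read-out higher numbers stand for lower toxicity in this test and lower numbers for higher toxicity in this test), was run on three compounds that share one core. Compound 1 `Nc1nn2c(O)cc(-c3cc([N+](=O)[O-])c(Cl)cc3Cl)nc2c1[N+](=O)[O-]` reaches only the limit of the test, > 100 ug/mL, which is not a number. Compound 2 `Nc1nn2c(O)cc(-c3ccc(F)cc3)nc2c1[N+](=O)[O-]` likewise reaches only the limit of > 100 ug/mL. Compound 3 `COc1ccc(NNCc2cc(O)n3nc(N)c([N+](=O)[O-])c3n2)cc1` gives a number, 66.3 ug/mL. Compound 2 thus stands at the limit of > 100 ug/mL in this assay, at which 2 of the 3 values shown sit. Compound 4 `Nc1nn2c(O)cc(CNCCO)nc2c1[N+](=O)[O-]` differs from compound 2 by ((2-hydroxyethyl)amino)methyl in place of 4-fluorophenyl on an aromatic carbon. Going by the values given here, no measured pair isolates such a change. The step is expected to stay within the usual scatter, a number no higher from compound 2 to compound 4 (the limit leaves the size open). Compound 4 is estimated at 100 ug/mL, with a range from 50 ug/mL to 200 ug/mL.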

Compound 4, half-maximal cytotoxic concentration: > 50 ug/mL
Compound 4: a limit, no number; the forecaster's own chance of this, stated with the estimate: 70%; the middle value is on the limit's open side.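

In this assay, going by these compounds alone, compound 2 and compound 4 both give only limits, and no step between them can be read. The compounds shown leave open what ((2-hydroxyethyl)amino)methyl in place of 4-fluorophenyl does to this read-out.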